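Benzyl in Place of Propyl in a Sulfonylurea Series

A few compounds are considered here, and "the series" means these few. Any claim that something is new, unique, unknown or untested is made for them only; others in the source may bear on it.

Measured compounds:
compound 1 `Cc1ccc(-c2ccc(=O)n(-c3ccc(S(=O)(=O)NC(=O)NCc4ccccc4)cc3)n2)cc1` — 119%
compound 2 `CCCNC(=O)NS(=O)(=O)c1ccc(-n2nc(-c3ccc(Cl)cc3)ccc2=O)cc1` — 122%
compound 3 `CCCCNC(=O)NS(=O)(=O)c1ccc(-n2nc(-c3ccc(Cl)cc3)ccc2=O)cc1` — 100%

Of the compounds shown here, three on a shared core have been measured in a functional assay on the whole organism (blood, strain Wistar albino) for inhibition, with Rattus norvegicus as the target, read by colorimetric assay, with stated times of 15 min and 90 min, at a dose of 20 mg/kg by the oral route; on this read-out lower numbers stand for less inhibition and higher numbers for more inhibition at the one dose given (going by the name of the read-out). Compound 2 gives 122%, compound 1 gives 119%, and compound 3 gives 100%, the lowest of the three, with both gaps to the other two beyond the scatter.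

Compound 4 `O=C(NCc1ccccc1)NS(=O)(=O)c1ccc(-n2nc(-c3ccc(Cl)cc3)ccc2=O)cc1` is not yet measured. It differs from compound 3 by phenyl in place of propyl on a saturated chain carbon bound to an amide-type nitrogen. Within the data shown here, one measured step bears on this change, though only loosely: a number 22 percentage points lower from compound 2 to compound 3 (beyond the scatter), where a methyl replaced hydrogen three bonds along the chain. Growing the chain there lowered the read-out. Among the measured compounds shown here, compound 1 carries the same benzyl group that enters here, on a core that differs in its aryl substituent, and gives 119%; no step is recorded between compound 1 and compound 4, so that value is only a pointer.

Because compound 1 gives 119%, compound 4 is expected to rise rather than fall. Compound 4 is estimated at 115%, with a range from 95% to 135%. The step that this estimate means, a number 15 percentage points higher from compound 3 to compound 4 (beyond the scatter), is expected to be beyond the scatter.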

Compound 4, a percentage reported as inhibition, in the whole organism at one dose (the size of the read-out at that dose, not a potency): 111%
For compound 4 the middle estimate is 4 percentage points above the measured one; measured number inside the range.
By their numbers in this assay, from the lowest: compound 3; then compounds 4, 1 and 2 (each within the scatter of the next, the first and the last beyond it).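

In this assay, phenyl in place of propyl on a saturated chain carbon bound to an amide-type nitrogen brings the number back up (a number 11 percentage points higher from compound 3 to compound 4 (beyond the scatter)), so the drop seen on growing the chain (a number 22 percentage points lower from compound 2 to compound 3 (beyond the scatter)) does not hold for every larger group at this place. Phenyl in place of ethyl at the same place still gives a drop (a number 11 percentage points lower from compound 2 to compound 4 (beyond the scatter)), so compound 4 with its benzyl group does not regain the full reading of compound 2 with its propyl group, and the three groups at this place give three readings set apart by more than the scatter. With the benzyl group kept, chloro in place of methyl on an aromatic carbon makes no clear difference (a number 8 percentage points lower from compound 1 to compound 4 (within the scatter)), so the two substituents cannot be told apart in this read-out.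

No measurement at hand explains why these groups read as they do. From the compounds shown here alone, it remains open whether a phenethyl or cyclohexylmethyl group at this place would follow benzyl or butyl, and whether an amine or a carboxylic acid on the phenyl ring would change the reading.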